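This account rests on a few compounds, and the source may have more. Where it says the series, first, only, none or still open, it means among the compounds named here.

Working notes on the series. In a physicochemical assay for lipophilicity, at pH 7 (on this read-out higher numbers stand for higher lipophilicity and lower numbers for lower lipophilicity), compound 1 `O=C(O)c1cc(-c2ccc(Cl)c(F)c2)ncn1` gives 0.4 and compound 2 `Cc1cccc(-c2cc(C(=O)O)ncn2)c1` gives -0.19, two values further apart than the usual scatter. As far as these compounds go, compound 3 `O=C(O)c1cc(-c2ccc(N3CCCC3)c(Cl)c2)ncn1` has no number to offer: its result reads "not determined" (no result reported), so its place stays open.

Compound 4 `O=C(O)c1cc(-c2ccc(OC3CCC3)c(Cl)c2)ncn1` is the next to be read, and the change is cyclobutyloxy in place of pyrrolidin-1-yl on an aromatic carbon. The swap sits ortho to a chloro group. For this swap, no step beyond the scatter is expected in this assay, in either direction, although the missing number for compound 3 means that no step can be read directly.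

The expectation therefore has to lean on the measured compounds. Compound 1 at 0.4 is the closer reference, as it also carries a chloro group, while compound 2 at -0.19 carries none. Neither measured compound carries pyrrolidin-1-yl or cyclobutyloxy, so the range is kept wide and placed mostly upward of compound 1.

For compound 4 the expected value is 0.9, with an estimated range of 0.3 to 1.5.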

Compound 4, partition coefficient: 1.19
Compound 4: middle estimate off by 0.29 log units, on the low side; low and high end bracket the measured number.
By their numbers in this assay, from the lowest: compound 2; then compound 1; then compound 4.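

No new step can be read between compound 3 and compound 4 in this assay on the compounds shown. These compounds leave open how cyclobutyloxy and pyrrolidin-1-yl compare on the shared core. No evidence at hand bears on the result for compound 4.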